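The source may hold more compounds than are shown below. What is called first, only, known or untested is meant among the compounds shown, and "the series" means these compounds.

Among the compounds with values here, in a functional assay on Bel-7402 cells (Homo sapiens) for antiproliferative activity, read by MTT assay, with a stated time of 72 h (a lower number here means a stronger inhibitor, a higher number a weaker inhibitor), only two compounds have been measured so far. Compound 1 `C=C1C(=O)O[C@H]2[C@H]1CC/C(COC(=O)Cn1cc(F)c(=O)[nH]c1=O)=C\CC[C@@]1(C)O[C@@H]21` gives > 20000 nM, which is a limit of the assay and not a number. Compound 2 `C=C1C(=O)O[C@H]2[C@H]1CC/C(Cn1cc(Cn3cc(F)c(=O)[nH]c3=O)nn1)=C\CC[C@@]1(C)O[C@@H]21` gives > 20000 nM, which is likewise only a limit. The record so far is therefore (the limit of > 20000 nM in this assay, at which 2 of the 2 values shown sit), and it offers no numerical starting point for the next compound.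

Compound 3 `C=C1C(=O)O[C@H]2[C@H]1CC/C(Cn1cc(Cn3cc(F)c(=O)n(Cc4ccc(F)cc4)c3=O)nn1)=C\CC[C@@]1(C)O[C@@H]21` differs from compound 2 in one place: 4-fluorobenzyl in place of hydrogen on an aromatic nitrogen, with 4-fluorobenzyl in place of hydrogen on an aromatic nitrogen. Within the data shown here, no measured step shows what this change does in this assay, so the expectation is loose: a modest move towards stronger inhibition, with a real chance of another limit. The expected step is an at least 2.2-fold lower number from compound 2 to compound 3 (0.34 log units; beyond the scatter). For compound 3 the estimated value is 9000 nM, with an expected range of 2500 nM to 20000 nM.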

Compound 3, half-maximal inhibitory concentration: 4910 nM
Compound 3: middle estimate off by 1.8-fold (0.26 log units), on the high side; the measured number falls inside the stated range.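

In this assay, within the data shown here, 4-fluorobenzyl in place of hydrogen on an aromatic nitrogen gives the first step that can be read, and it lies beyond the scatter: an at least 4.0-fold lower number from compound 2 to compound 3 (0.60 log units; beyond the scatter). This shows that the position, on the six-membered aromatic ring with 2 nitrogen, is open to a large group, and that such a group can bring a measurable number into a series that had shown only limits. Compound 2 gives > 20000 nM, which is a limit of the assay and not a number, so the full size of the step remains unknown, and the record still rests largely on that limit: the limit of > 20000 nM in this assay, at which 2 of the 3 values shown sit.

Going by these compounds, how plain benzyl, methyl or a longer alkyl chain on that nitrogen would compare with 4-fluorobenzyl stays open. So does whether the same change would give a similar step on compound 1.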